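The compounds below may be only part of what the source reports. "The series", "measured", "known", "first", "only" and "open" are said of these compounds alone.

In a functional assay on cells (leukaemia cell line, Homo sapiens) for inhibition, read by sulforhodamine B assay, with a stated time of 48 h (on this read-out higher numbers stand for weaker inhibition of growth and lower numbers for stronger inhibition of growth), compound 1 `O=S(=O)(Nc1ccc(F)cc1F)c1ccc(-c2cnc(C3CC3)o2)cc1` gives 66100 nM. Compound 2 `O=S(=O)(Nc1cc(Cl)ccc1Cl)c1ccc(-c2cnc(C3CC3)o2)cc1` gives > 100000 nM, which is a limit of the assay and not a number. Compound 3 `O=S(=O)(Nc1ccc(I)c(Cl)c1)c1ccc(-c2cnc(C3CC3)o2)cc1` carries 3-chloro-4-iodophenyl in place of 2,5-dichlorophenyl on a sulfonamide nitrogen. Among the measured compounds shown here, the one measured step that bears on this change is also a swap on that nitrogen: an at least 1.5-fold higher number from compound 1 to compound 2 (0.17 log units; that floor lies within the scatter). For the measured compounds named here, with only that small step as a guide, no change beyond the scatter is expected in this assay, and the estimated step is an at least 1.5-fold lower number from compound 2 to compound 3 (0.18 log units; that floor lies within the scatter). For compound 3, the expected value is 65000 nM, within an estimated range of 25000 nM to 100000 nM.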

Compound 3, concentration for total growth inhibition: 19600 nM
Compound 3: middle estimate off by 3.3-fold (0.52 log units), on the high side; the whole stated range lies above it.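

The earlier pair showed no step beyond the scatter, but in this assay the group on the sulfonamide nitrogen now clearly matters: with 3-chloro-4-iodophenyl there is a 3.4-fold lower number from compound 1 to compound 3 (0.53 log units; beyond the scatter), and an at least 5.1-fold lower number from compound 2 to compound 3 (0.70 log units; beyond the scatter). The second step is only a floor, as compound 2 stands at a limit and not a number: the limit of > 100000 nM in this assay, at which 1 of the 3 values shown sits.

The compounds shown do not separate the chlorine from the iodine of 3-chloro-4-iodophenyl. Going by these compounds, how an amine or a carboxylic acid on that phenyl ring would read in this assay also stays open.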